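Moving the fluorine on the aryl ring of an mGlu5 modulator

The source may report more compounds than this note shows. Statements on the series, on what has been measured and on what is new or still open speak of the compounds shown alone.

Compound 1 `O=C1CC(c2nc(-c3ccc(F)cc3)no2)CN1c1ccc(Cl)cc1` is one of two compounds tested in an in vitro functional assay on HEK293-A cells for positive allosteric modulation of metabotropic glutamate receptor 5 (Homo sapiens), read by FLIPR and calcium flux; on this read-out higher numbers stand for an effect only at larger amounts of compound and lower numbers for an effect already at smaller amounts. In this assay compound 1 gives 1700 nM, which is the lower of the two numbers. Its companion, compound 2 `O=C1CC(c2nc(-c3ccc(F)cc3)no2)CN1c1ccc(Cl)c(Cl)c1`, carries an added chloro on an aromatic carbon of the ring attached to the lactam nitrogen; in this assay compound 2 gives 2300 nM, and the step of a 1.4-fold higher number from compound 1 to compound 2 (0.13 log units; within the scatter) is too small to count as a real difference.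

Compound 3 `O=C1CC(c2nc(-c3cccc(F)c3)no2)CN1c1ccc(Cl)cc1` has not yet been measured. It differs from compound 1 only in the ring on the five-membered aromatic ring: 3-fluorophenyl in place of 4-fluorophenyl on an aromatic carbon. Among the measured compounds shown here, the one measured step concerns a different part of the molecule, the chloro added on the other aromatic ring, and so says nothing about shifting a fluorine within the 4-fluorophenyl group. There is therefore no measured guide for this change, and the working expectation is a step of a 1.2-fold higher number from compound 1 to compound 3 (0.07 log units; within the scatter), that is, nothing clearly beyond the scatter, with a wide margin in both directions. On that basis compound 3 is estimated to give 2000 nM in this assay, within a range from 600 nM to 7000 nM.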

Compound 3, half-maximal effective concentration: 630 nM
Beside the measured number, compound 3's estimate is 3.2-fold (0.50 log units) above it; low and high end bracket the measured number.
By their numbers in this assay, from the lowest: compound 3; then compounds 1 and 2 (each within the scatter of the next).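

In this assay, swapping 4-fluorophenyl for 3-fluorophenyl gives a 2.7-fold lower number from compound 1 to compound 3 (0.43 log units; beyond the scatter), so at this place on the five-membered ring the result depends on where the fluorine sits on the phenyl group, even though the group that leaves and the group that enters have the same atoms. The earlier step, a chloro added on the other aromatic ring, gave a 1.4-fold higher number from compound 1 to compound 2 (0.13 log units; within the scatter), so this is the first change among the compounds shown that moves the number beyond the scatter, and it does so without adding or removing a single atom. Nothing measured here explains why the fluorine's location matters, so the result stands as an observation without a known cause.

The compounds shown cover only two fluorophenyl groups at this place, which leaves open how 2-fluorophenyl, or a phenyl carrying chloro, methoxy or nitrile instead of fluorine, would compare with 3-fluorophenyl. Also open, going by these compounds, is whether the same swap would give a similar step on compound 2, which carries the added chloro, since the two changes have so far been seen only separately.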